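Methoxy on the pendant phenyl of the shared core

The source may report more compounds than this note shows. Statements on the series, on what has been measured and on what is new or still open speak of the compounds shown alone.

Compound 1 `COc1cc(/C=C/C(=O)c2cccc(-n3cc(-c4ccccc4)[nH]c3=O)c2)ccc1O`: 6810 nM
Compound 2 `O=C(/C=C/c1cccc(O)c1)c1cccc(-n2cc(-c3ccccc3)[nH]c2=O)c1`: 7680 nM
Compound 3 `COc1cc(/C=C/C(=O)c2cccc(-n3cc(-c4ccccc4)[nH]c3=O)c2)cc(OC)c1OC`: 1520 nM

In a functional assay on UACC-257 cells (Homo sapiens) for inhibition (on this read-out higher numbers stand for weaker inhibition of growth and lower numbers for stronger inhibition of growth), compound 1 gives 6810 nM, the second highest of the three numbers. Its nearest neighbour is compound 2, where a 1.1-fold higher number from compound 1 to compound 2 (0.05 log units; within the scatter). Compound 3, with its trimethoxyphenyl on the chain, gives 1520 nM, a lower number than compound 1 and beyond the scatter.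

Compound 4 `COc1ccc(-c2cn(-c3cccc(C(=O)/C=C/c4ccc(O)c(OC)c4)c3)c(=O)[nH]2)cc1` differs from compound 1 at the other end of the core: methoxy in place of hydrogen on an aromatic carbon, on an aromatic carbon of a six-membered aromatic ring of carbon only, para to a large group. Going by the values given here, none of the measured steps touches this ring; the one step on record, from compound 1 to compound 2, changes the aryl group on the chain and stays within the scatter, and the gap between compound 1 and compound 3 also arises on the chain. Among the compounds with values here, there is thus no precedent for the change, and a small methoxy entering an otherwise unchanged core is expected to move the number little. Compound 4 is therefore estimated at 5000 nM, within 2000 nM to 14000 nM. The expected step is a 1.4-fold lower number from compound 1 to compound 4 (0.13 log units; within the scatter), in either direction and most likely within the scatter.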

Compound 4, concentration for 50% growth inhibition: 13300 nM
Beside the measured number, compound 4's estimate is 2.7-fold (0.42 log units) below it, within the range that was stated.
By their numbers in this assay, from the lowest: compound 3; then compounds 1, 2 and 4 (each within the scatter of the next).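

Going by these compounds alone, this gives the first reading at this end of the shared core. In this assay, methoxy in place of hydrogen on an aromatic carbon, para to a large group, gives a 2.0-fold higher number from compound 1 to compound 4 (0.29 log units; within the scatter), so on this single pair the change from phenyl to 4-methoxyphenyl cannot be told apart from repeat measurement. The earlier compounds shown here varied only the aryl group on the chain, so they said nothing about this ring, and this step now shows that the ring can carry a methoxy group without a change that stands clear of the scatter. Nothing in the data shown here gives a measured reason for this outcome.

One pair on the core of compound 1 cannot show whether the same change would read the same way with the trimethoxyphenyl group of compound 3 on the chain. It also leaves open how this place, on the same six-membered aromatic ring of carbon only, would respond to an amine, a carboxylic acid or a longer alkoxy chain in place of the methoxy.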